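Swapping the Nitrile-Bearing Ring on the Sulfonyl Linker

The compounds below may be only part of what the source reports. "The series", "measured", "known", "first", "only" and "open" are said of these compounds alone.

Measured compounds:
compound 1 `COc1ccc2ncc(S(=O)(=O)c3cccc(C#N)c3)c(N3CCC(C)CC3)c2c1`, 90%
compound 2 `CC1CCN(c2c(S(=O)(=O)c3cccc(C#N)c3)cnc3ccc(Cl)cc23)CC1`, 90%
compound 3 `Cc1ccc2ncc(S(=O)(=O)c3ccc(F)c(Cl)c3)c(N3CCC(C)CC3)c2c1`, 93%

In an assay on isolated protein for displacement of a labelled ligand from metabotropic glutamate receptor 5 (Homo sapiens), with a stated time of 60 min, tested at 1 uM (on this read-out lower numbers stand for less inhibition and higher numbers for more inhibition at the one concentration tested (going by the name of the read-out)), compound 1 gives 90%, level with compound 2 and also within the scatter of compound 3. Compound 4 `COc1ccc2ncc(S(=O)(=O)c3ccc(C)c(Cl)c3)c(N3CCC(C)CC3)c2c1` differs from compound 1 in 3-chloro-4-methylphenyl in place of 3-cyanophenyl on a sulfonyl sulfur. For the measured compounds named here, no measured pair isolates this change. Going by the values given here, the one step on record, no change at the digits printed from compound 1 to compound 2 (within the scatter), alters the shared core rather than the ring on the sulfonyl sulfur and lies within the scatter. Compound 3 carries a different ring on its sulfonyl sulfur and gives 93%. All three numbers are high and close together, so compound 4 is expected to remain in that range. The step of no change at the digits printed from compound 1 to compound 4 (within the scatter) is expected to lie within the scatter. The estimate for compound 4 is 90%, between 80% and 97%.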

Compound 4, a percentage reported as inhibition, at one concentration (the size of the read-out at that concentration, not a potency): 85%
Estimate against measurement, compound 4: 5 percentage points above, within the range that was stated.
By their numbers in this assay, from the lowest: compounds 4, 1, 2 and 3 (each within the scatter of the next).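

Unlike the earlier step, which altered the shared core, this pair changes only the ring on the sulfonyl sulfur: with 3-chloro-4-methylphenyl in place of 3-cyanophenyl, this assay gives a number 5 percentage points lower from compound 1 to compound 4 (within the scatter). The nitrile is therefore not required for a high reading on the core of compound 1. No measurement on record explains why the two rings read alike.

Going by these compounds, whether a ring bearing an amine or a carboxylic acid would read the same remains open. On these data alone, each number comes from one concentration, so any difference in potency also remains open.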